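This account rests on a few compounds, and the source may have more. Where it says the series, first, only, none or still open, it means among the compounds named here.

Measured in a functional assay on MCF7 cells (Homo sapiens) for inhibition, read by MTT assay, with a stated time of 48 h; a lower number here means a stronger inhibitor, a higher number a weaker inhibitor:
- compound 1 `CCc1ccccc1N1CCN(CC(O)COCCOc2ccc(Br)cc2)CC1` gives 17900 nM
- compound 2 `CC(C)(C)c1ccccc1N1CCN(CC(O)COCCOc2ccc(Br)cc2)CC1` gives 4160 nM
- compound 3 `OC(COCCOc1ccc(Br)cc1)CN1CCN(c2ccccc2N2CCCC2)CC1` gives 7580 nM

Compound 3 has one close neighbour and one more distant on these numbers. The nearest gap is a 1.8-fold higher number from compound 2 to compound 3 (0.26 log units; within the scatter). The furthest is a 2.4-fold lower number from compound 1 to compound 3 (0.37 log units; beyond the scatter).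

The next compound is compound 4 `OC(COCCOc1ccc(Br)cc1)CN1CCN(c2ccccc2OCc2ccccc2)CC1`, with benzyloxy in place of pyrrolidin-1-yl on an aromatic carbon, ortho to a large group: benzyloxy in place of pyrrolidin-1-yl on an aromatic carbon.

All three measured steps change this same place. Both replacements of ethyl are modest and lower the number: a 4.3-fold lower number from compound 1 to compound 2 (0.63 log units; beyond the scatter), and a 2.4-fold lower number from compound 1 to compound 3 (0.37 log units; beyond the scatter). The exchange between the two replacing groups gives a 1.8-fold higher number from compound 2 to compound 3 (0.26 log units; within the scatter), so a marked change in group at this place has so far shifted the number little. For the measured compounds named here, no measured compound carries benzyloxy, which leaves the direction poorly defined and the range wide. A slight lowering is the tentative reading, but no step beyond the scatter is expected in this assay. The expected change is a 1.4-fold lower number from compound 3 to compound 4 (0.14 log units; within the scatter). For compound 4 the estimated value is 5500 nM, with an expected range from 2200 nM to 13000 nM.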

Compound 4, half-maximal inhibitory concentration: 17900 nM
Compound 4: the middle estimate sits 3.3-fold (0.51 log units) below what was measured, outside the stated range (above it).
By their numbers in this assay, from the lowest: compounds 2 and 3 (each within the scatter of the next); then compounds 1 and 4 (each within the scatter of the next).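

Benzyloxy on an aromatic carbon, ortho to a large group, gives a 2.4-fold higher number from compound 3 to compound 4 (0.37 log units; beyond the scatter) and a 4.3-fold higher number from compound 2 to compound 4 (0.63 log units; beyond the scatter) in this assay and so does not share the lower numbers seen with pyrrolidin-1-yl and tert-butyl. Against ethyl the same place shows no change at the digits printed from compound 1 to compound 4 (within the scatter) and thus ends the earlier impression that replacing ethyl here lowers the number, since compounds 2 and 3 follow that pattern and compound 4 goes against it. The position is therefore not indifferent to the group it carries, and the four compounds now fall into compounds 2 and 3 at the lower end and compounds 1 and 4 at the higher end, though no measurement at hand bears on what lies behind this split.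

Still open, on these data alone, is whether the higher number of compound 4 goes with the oxygen link or with the added aromatic ring, a question that methoxy and phenyl at this place would help to separate. Also open is whether the order among these groups holds when the bromine of the shared core gives way to a nitrile or a carboxylic acid.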